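Swapping the amine at the end of a flexible chain

The source may hold more compounds than are shown below. What is called first, only, known or untested is meant among the compounds shown, and "the series" means these compounds.

Of the compounds shown here, three share a core and have been tested in a functional assay on B16 cells (Mus musculus) for cytotoxicity, read by MTT assay, with a stated time of 72 h; on this read-out higher numbers stand for weaker inhibition and lower numbers for stronger inhibition. Compound 3, `O=c1cc(-c2ccccc2)oc2c(OCCCN3CCCC3)c(OCc3ccccc3)cc(O)c12`, gives 7980 nM. Compound 1, `COc1c(OCCCCN2CCN(C)CC2)cc(O)c2c(=O)cc(-c3ccc(C)cc3)oc12`, gives 5430 nM, and compound 2, `COc1c(OCCCCN2CCN(C)CC2)cc(O)c2c(=O)cc(-c3cccc(F)c3)oc12`, gives 4520 nM; neither gap from compound 3 exceeds the usual scatter, so the three sit together. Among the compounds with values here, the single measured step, a 1.2-fold lower number from compound 1 to compound 2 (0.08 log units; within the scatter), concerns the pendant aromatic group and says nothing about the amine at the chain end. Compound 4, `CN(C)CCCCOc1c(OCc2ccccc2)cc(O)c2c(=O)cc(-c3ccccc3)oc12`, differs from compound 3 by (dimethylamino)methyl in place of pyrrolidin-1-yl on a saturated chain carbon, three bonds along the chain from an oxygen on an aromatic ring. Within the data shown here, with no measured step bearing on this change, no shift beyond the scatter is expected. Compound 4 is therefore estimated at 8000 nM, likely between 3500 nM and 18000 nM. That estimate amounts to an expected step of a 1.0-fold higher number from compound 3 to compound 4 (0.00 log units; within the scatter).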

Compound 4, half-maximal inhibitory concentration: 3220 nM
The estimate for compound 4 lay 2.5-fold (0.40 log units) above the measured number; measured number outside the range, below it.
By their numbers in this assay, from the lowest: compounds 4, 2, 1 and 3 (each within the scatter of the next, the first and the last beyond it).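

In this assay, within the data shown here, this change gives the first step here beyond the scatter (a 2.5-fold lower number from compound 3 to compound 4 (0.39 log units; beyond the scatter)), so the end of this chain does affect the number, if modestly. Read along the whole side chain, the change is 3-(pyrrolidin-1-yl)propyl to 4-(dimethylamino)butyl, so the amine and the chain length change together. No supporting evidence accounts for the step.

A 3-(dimethylamino)propyl or a 4-(pyrrolidin-1-yl)butyl chain would separate these two changes. From the compounds shown here alone, how a piperidine or morpholine at the chain end would compare remains open.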